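Hydroxy-to-methoxy step on the aryl ring of the series

The source may hold more compounds than are shown below. What is called first, only, known or untested is meant among the compounds shown, and "the series" means these compounds.

Measured compounds:
- compound 1 `COc1cc(O)cc(-c2nc3cccnc3n(CC(=O)O)c2=O)c1`, "not determined" (no result reported)
- compound 2 `COc1ccc(-c2nc3cccnc3n(CC(=O)O)c2=O)cc1O`, 32.1%
- compound 3 `COc1c(O)cc(-c2nc3cccnc3n(CC(=O)O)c2=O)cc1O`, 45.6%

In a functional assay, read by spectrophotometry, with a stated time of 30 min, tested at 100 uM (a higher number here means a stronger effect of the compound at the concentration tested, a lower number a weaker effect), compound 3 gives 45.6%, the highest of the two numbers available; compound 2 gives 32.1%, and compound 1 gives "not determined" (no result reported). Among the measured compounds shown here, the one step recorded, a number 13.5 percentage points higher from compound 2 to compound 3 (beyond the scatter), follows the entry of a hydroxy on an aromatic carbon.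

Compound 4 `COc1cc(-c2nc3cccnc3n(CC(=O)O)c2=O)cc(O)c1OC` differs from compound 3 as follows: methyl in place of hydrogen on an oxygen on an aromatic ring. For the measured compounds named here, no measured pair describes a hydroxy becoming a methoxy, so the step from compound 3 to compound 4 has no direct precedent; the only recorded step concerns a hydroxy entering rather than being capped. The expectation is therefore uncertain, leaning toward a loss of activity since the hydroxy that separates compound 2 from compound 3 is here converted, so a step of about a number 15.6 percentage points lower from compound 3 to compound 4 (beyond the scatter) is expected for compound 4 in this assay. Compound 4 is estimated at 30%, within the range 10% to 55%.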

Compound 4, a percentage reported as activity, at one concentration (the size of the read-out at that concentration, not a potency): 20.5%
For compound 4 the middle estimate is 9.5 percentage points above the measured one; the range from low to high includes it.
By their numbers in this assay, from the lowest: compound 4; then compound 2; then compound 3.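

Oxygen on this aromatic carbon does not by itself carry the gain seen with the hydroxy: in this assay, methyl in place of hydrogen on that oxygen gives a number 25.1 percentage points lower from compound 3 to compound 4 (beyond the scatter). Set against the hydrogen of compound 2, the methoxy gives a number 11.6 percentage points lower from compound 2 to compound 4 (beyond the scatter), while the hydroxy gives a number 13.5 percentage points higher from compound 2 to compound 3 (beyond the scatter), so the two groups move the number in opposite directions from the same starting compound. The step up therefore depends on the oxygen staying a hydroxy, at least across these three compounds.

From the compounds shown here alone, whether an amine, a fluorine or a longer chain such as ethoxy at this place would fall with the methoxy or rise with the hydroxy remains open. Nothing available explains why the methyl lowers the number.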